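The source may report more compounds than this note shows. Statements on the series, on what has been measured and on what is new or still open speak of the compounds shown alone.

Working notes on the series. Compound 1 `CC[C@H](C)[C@H](NCCC1OCC(C)(C)CO1)C(=O)N[C@H]1[C@@H](OC(C)=O)O[C@H](COC(C)=O)[C@@H](OC(C)=O)[C@@H]1OC(C)=O` is run in a functional assay on the whole organism (Ear, strain ICR) for inhibition, with Mus musculus as the target, with stated times of 30 min and 2 h, at a dose of 10 umol/kg by the oral route (on this read-out lower numbers stand for less inhibition and higher numbers for more inhibition at the one dose given (going by the name of the read-out)), where compound 1 gives 79.8%. Compound 2 `CC(=O)OC[C@H]1O[C@H](OC(C)=O)[C@H](NC(=O)[C@@H](NCCC2OCC(C)(C)CO2)C(C)C)[C@@H](OC(C)=O)[C@@H]1OC(C)=O` keeps the core of compound 1 and differs from it only by hydrogen in place of methyl on a saturated chain carbon, three bonds along the chain from an amine nitrogen and a carbonyl carbon; in this assay compound 2 gives 70.6%. The resulting step is a number 9.2 percentage points lower from compound 1 to compound 2 (within the scatter).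

Compound 3 `CC[C@H](C)[C@H](NCCC1OCC(C)(C)CO1)C(=O)N[C@H]1C(O)O[C@H](CO)[C@@H](O)[C@@H]1O` sits on a different core; the difference between the two cores is not broken down here. In this assay compound 3 gives 88.7%. Its gap to compound 1 is within the scatter, while its gap to compound 2 lies beyond it.

Compound 4 `CC(C)[C@H](NCCC1OCC(C)(C)CO1)C(=O)N[C@H]1C(O)O[C@H](CO)[C@@H](O)[C@@H]1O` has not been measured. It stands to compound 3 as compound 2 stands to compound 1: the change is hydrogen in place of methyl on a saturated chain carbon, three bonds along the chain from an amine nitrogen and a carbonyl carbon, the same change at the same place, now on the core of compound 3. For compound 4 a step of about the size already seen is expected, a number 8.7 percentage points lower from compound 3 to compound 4 (within the scatter), because the earlier step on the other core was a number 9.2 percentage points lower from compound 1 to compound 2 (within the scatter). Compound 4 is therefore estimated to give 80% in this assay, expected to fall between 68% and 92%.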

Compound 4, a percentage reported as inhibition, in the whole organism at one dose (the size of the read-out at that dose, not a potency): 85.1%
For compound 4 the middle estimate is 5.1 percentage points below the measured one, and the stated range covers the measured number.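

In this assay, the change from sec-butyl to isopropyl gives a number 3.6 percentage points lower from compound 3 to compound 4 (within the scatter). Set beside the earlier step on the other core, the two steps do not differ: the same change on two cores in this assay, a number 9.2 percentage points lower (within the scatter) from compound 1 to compound 2 and a number 3.6 percentage points lower (within the scatter) from compound 3 to compound 4, 5.6 percentage points apart, within the scatter of two such steps. On these two cores the change therefore carries over with no difference that can be told from the scatter, but neither step on its own shows a real effect of the change, and two pairs at one dose do not show that the step would hold on any further core.

The compounds shown leave open how the read-out responds when sec-butyl gives way to something other than isopropyl, such as a longer chain, a benzyl group, or a chain carrying an amine or a carboxylic acid. They also leave open how these compounds rank in potency, since each number comes from a single dose.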